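From Methyl to Ethyl on the Shared Core

The compounds below may be only part of what the source reports. "The series", "measured", "known", "first", "only" and "open" are said of these compounds alone.

Measured compounds:
compound 1 `Cc1nnc2nnc(N3CCCC3)nn12` — 5360 nM
compound 2 `O=[N+]([O-])c1ccc(-c2nnc3nnc(N4CCCCC4)n3n2)cc1` — > 100000 nM

Of the compounds shown here, two have been measured in a functional assay on BeWo cells (Homo sapiens) for cytotoxicity, read by MTT assay, with a stated time of 72 h; on this read-out lower numbers stand for stronger inhibition and higher numbers for weaker inhibition. Compound 1 gives 5360 nM in this assay, and this is the only number shown among the two values. Compound 2 gives > 100000 nM, which is a limit of the assay rather than a number; that value is the limit of > 100000 nM in this assay, at which 1 of the 2 values shown sits. So compound 1 stands alone with a real number, and no step between two measured compounds is available to size any single change.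

Compound 3 `CCc1nnc2nnc(N3CCCC3)nn12` is yet to be measured in this assay. It differs from compound 1 by methyl in place of hydrogen on a saturated chain carbon bound to an aromatic carbon. Within the data shown here, with no measured step of this kind to draw on, the expected step of a 1.1-fold lower number from compound 1 to compound 3 (0.03 log units; within the scatter) is small, in no clear direction, and not beyond the usual scatter. Compound 3 is therefore estimated at 5000 nM, with a range from 1500 nM to 16000 nM.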

Compound 3, half-maximal inhibitory concentration: 5020 nM
Compound 3: middle estimate off by 1.0-fold (0.00 log units), on the low side; the range from low to high includes it.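

In this assay the change from methyl to ethyl on the shared core gives a 1.1-fold lower number from compound 1 to compound 3 (0.03 log units; within the scatter) and so leaves the two compounds indistinguishable on this read-out. Among these compounds, this is the first measured step at this place, a saturated chain carbon bound to an aromatic carbon, and it shows that an added methyl there does not move the number beyond the usual scatter. Among the compounds shown here, nothing measured so far offers an explanation for this result.

One small step cannot show how far this tolerance reaches, so a longer chain such as propyl or butyl could behave differently. Going by these compounds, whether an amine or a carboxylic acid at the end of the chain would keep the cytotoxic effect, raise it or lose it also remains open.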